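Ethylamino for anilino on the core of compound 1

The compounds below may be only part of what the source reports. "The series", "measured", "known", "first", "only" and "open" are said of these compounds alone.

Compound 1 `CCOc1ccc(NC(=O)c2c(N)n[nH]c2Nc2ccccc2)cc1` gives 21000 nM in a functional assay on PANC-1 cells (Homo sapiens) for cytotoxicity, read by resazurin assay, with a stated time of 48 h; a lower number here means a stronger inhibitor, a higher number a weaker inhibitor. Compound 2 `C=CCN/C(SC)=C(/C#N)C(=O)Nc1ccc(OCC)cc1` gives 21800 nM and compound 3 `CCN/C(SC)=C(/C#N)C(=O)Nc1ccc(OCC)cc1` gives 41600 nM, so compound 1 sits within the scatter of both. Among the compounds with values here, the one measured step, a 1.9-fold higher number from compound 2 to compound 3 (0.28 log units; within the scatter), also stays within the scatter. Compound 4 `CCNc1[nH]nc(N)c1C(=O)Nc1ccc(OCC)cc1` differs from compound 1 in one place: ethyl in place of phenyl on a nitrogen on an aromatic ring. Within the data shown here, no measured step touches the nitrogen on the aromatic ring; the step from compound 2 to compound 3 changes a group on a saturated chain carbon bound to an amine nitrogen and showed nothing beyond the scatter. No step beyond the scatter is therefore expected in this assay, with a wider range for the untested position. Compound 4 is expected to give 30000 nM, between 10000 nM and 90000 nM. That estimate means an expected step of a 1.4-fold higher number from compound 1 to compound 4 (0.15 log units; within the scatter).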

Compound 4, half-maximal inhibitory concentration: 14800 nM
Beside the measured number, compound 4's estimate is 2.0-fold (0.31 log units) above it; low and high end bracket the measured number.
By their numbers in this assay, from the lowest: compounds 4, 1, 2 and 3 (each within the scatter of the next, the first and the last beyond it).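

Within the data shown here, the step of a 1.4-fold lower number from compound 1 to compound 4 (0.15 log units; within the scatter) in this assay is the first reading at this position and stays within the scatter. On this nitrogen on an aromatic ring, for this pair, the phenyl ring can give way to ethyl with no change beyond the scatter, so anilino is not needed to keep the number in this range. Nothing measured explains this result.

As far as these compounds go, whether a longer chain such as butyl, a chain ending in an amine, or a carboxylic acid on this nitrogen would go beyond the scatter remains open. So does a plain amino group there.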